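Extending the Pentyloxy Chain of Compound 3

The compounds below may be only part of what the source reports. "The series", "measured", "known", "first", "only" and "open" are said of these compounds alone.

Of the compounds shown here, three built on a shared core have been measured in a functional assay on brain (Rattus norvegicus, strain Wistar) for inhibition; a lower number here means a stronger inhibitor, a higher number a weaker inhibitor. Compound 1 (`CCCCc1ccc(-c2c(C)[nH]c(=O)n2C)cc1`), which carries a butyl group, gives 10700 nM. Compound 2 (`Cc1[nH]c(=O)n(C)c1-c1ccc(CC(C)C)cc1`), which carries an isobutyl group, gives 7800 nM. Compound 3 (`CCCCCOc1ccc(-c2c(C)[nH]c(=O)n2C)cc1`), which carries a pentyloxy group, gives 4500 nM. This places compound 3 level with compound 2 at the low end of the numbers, since the data show a 1.7-fold lower number from compound 2 to compound 3 (0.24 log units; within the scatter). Compound 1 stands clearly apart, with a 2.4-fold lower number from compound 1 to compound 3 (0.38 log units; beyond the scatter).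

Compound 4 (`CCCCCCOc1ccc(-c2c(C)[nH]c(=O)n2C)cc1`) has not been measured yet. Its structural change is methyl in place of hydrogen on a saturated chain carbon, five bonds along the chain from an oxygen on an aromatic ring. Cut one bond further out, the same difference reads propyl to butyl.

For the measured compounds named here, no measured step isolates this change. The nearest guides are a 2.4-fold lower number from compound 1 to compound 3 (0.38 log units; beyond the scatter), which is modest and also swaps the group on the aromatic carbon, and a 1.4-fold lower number from compound 1 to compound 2 (0.14 log units; within the scatter), which reshapes a chain. Neither is large, so only a small shift is expected in this assay, perhaps toward a lower number. The expected step is a 1.3-fold lower number from compound 3 to compound 4 (0.10 log units; within the scatter). For compound 4 the estimated value is 3600 nM, within an expected range of 1800 nM to 7500 nM.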

Compound 4, half-maximal inhibitory concentration: 7300 nM
Estimate against measurement, compound 4: 2.0-fold (0.31 log units) below; low and high end bracket the measured number.
By their numbers in this assay, from the lowest: compounds 3, 4, 2 and 1 (each within the scatter of the next, the first and the last beyond it).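

In this assay, the hexyloxy chain of compound 4 isolates a single added methyl at this position, five bonds along the chain from an oxygen on an aromatic ring, and the result is a 1.6-fold higher number from compound 3 to compound 4 (0.21 log units; within the scatter), so this one-carbon extension produces no change that can be told apart from assay noise. Swapping the group on the aromatic carbon also stays within the scatter for hexyloxy, with a 1.1-fold lower number from compound 2 to compound 4 (0.03 log units; within the scatter) and a 1.5-fold lower number from compound 1 to compound 4 (0.17 log units; within the scatter), whereas the pentyloxy of compound 3 was the only group to stand beyond the scatter of the butyl of compound 1, so the oxygen-linked chains as a pair do not separate cleanly from the carbon chains. No information is available that would explain this result.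

As far as these compounds go, it remains open whether a longer chain, such as octyloxy, would keep the number in this same range or finally move it beyond the scatter. Equally open, from the compounds shown here alone, is what an amine or a carboxylic acid at the far end of the chain would do to the number in this assay.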